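From bromo to chloro on the carboxy compound

The source may hold more compounds than are shown below. What is called first, only, known or untested is meant among the compounds shown, and "the series" means these compounds.

Within the data shown here, in an ADME assay on a cell-free system (plasma, Rattus norvegicus, strain Sprague-Dawley) for metabolic stability, read by LC-MS, with a stated time of 120 min, tested at 1 uM (on this read-out lower numbers stand for a less stable compound and higher numbers for a more stable compound), compound 3 `CC#CCn1c(N2CCC[C@@H](N)C2)nc2c1c(=O)n(Cc1ccc(Br)cc1C(=O)O)c(=O)n2C` gives 98.3%, the highest of the three numbers so far. Its ethyl ester, compound 1 `CC#CCn1c(N2CCC[C@@H](N)C2)nc2c1c(=O)n(Cc1ccc(Br)cc1C(=O)OCC)c(=O)n2C`, gives 62.2%. Compound 2 `CC#CCn1c(N2CCC[C@@H](N)C2)nc2c1c(=O)n(Cc1ccc(Cl)cc1C(=O)OCc1oc(=O)oc1C)c(=O)n2C`, which carries chloro and a different ester, gives 1.25%.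

Compound 4 `CC#CCn1c(N2CCC[C@@H](N)C2)nc2c1c(=O)n(Cc1ccc(Cl)cc1C(=O)O)c(=O)n2C` differs from compound 3 in one place: chloro in place of bromo on an aromatic carbon. This is chloro in place of bromo on an aromatic carbon, meta to a carboxy group, and the carboxy group itself stays.

Among the measured compounds shown here, the only measured single-place step, a number 36.1 percentage points higher from compound 1 to compound 3 (beyond the scatter), is large, but it replaces ethyl with hydrogen and leaves the halogen untouched. For the measured compounds named here, no measured step swaps bromo for chloro, and compound 2 cannot fill that gap, since its ester differs too. Nothing therefore points to a shift in either direction in this assay. The expected change is small, within the scatter: a number 1.3 percentage points lower from compound 3 to compound 4 (within the scatter). The estimate for compound 4 is 97%, with an expected range from 87% to 104%.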

Compound 4, percent of the compound remaining in the Rattus norvegicus assay: 102%
Compound 4: the middle estimate sits 5 percentage points below what was measured; low and high end bracket the measured number.
By their numbers in the Rattus norvegicus assay, from the lowest: compound 2; then compound 1; then compounds 3 and 4 (each within the scatter of the next).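

Swapping the halogen directly at this place on the ring, meta to a carboxy group, makes no difference beyond the scatter in the Rattus norvegicus assay (a number 3.7 percentage points higher from compound 3 to compound 4 (within the scatter)) or in a physicochemical assay for metabolic stability, read by LC-MS, in phosphate buffer, with a stated time of 120 min, at pH 7.4, tested at 1 uM; on this read-out higher numbers stand for a more stable compound and lower numbers for a less stable compound (a number 1.8 percentage points higher from compound 3 to compound 4 (within the scatter)), where compound 3 gives 99.2% and compound 4 gives 101%. With chloro on both compounds, a hydrogen atom in place of a group of 8 heavy atoms, on an oxygen next to a carbonyl group, gives a large step in the Rattus norvegicus assay (a number 100.8 percentage points higher from compound 2 to compound 4 (beyond the scatter)). The step in the Rattus norvegicus assay (a number 39.8 percentage points higher from compound 1 to compound 4 (beyond the scatter)) changes both the halogen and the ester and cannot be read as a single change, and nothing measured here explains these numbers.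

The compounds shown hold only bromo and chloro at this place, so the outcome with fluoro, methyl or a nitrile stays open. As far as these compounds go, whether the swap matters when an ethyl ester replaces the carboxy group also stays open.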